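Imidazol-1-yl for phenyl: expected antiproliferative potency

The compounds below may be only part of what the source reports. "The series", "measured", "known", "first", "only" and "open" are said of these compounds alone.

Compound 1 `COc1ccc(C(=O)/C=C/c2cc(OC)c(OC)c(OC)c2)c2c1C=CC(C)(C)O2` gives 9700 nM in a functional assay on SK-OV-3 cells (Homo sapiens) for antiproliferative activity, read by MTT assay, with a stated time of 24 h; a higher number here means a weaker inhibitor, a lower number a stronger inhibitor. Compound 2 `COc1ccc(C(=O)/C=C/c2ccc(Br)cc2)c2c1C=CC(C)(C)O2` reaches only the assay limit > 10000 nM in this assay. Compound 3 `COc1ccc(C(=O)/C=C/c2ccc(-c3ccccc3)cc2)c2c1C=CC(C)(C)O2` likewise sits at the limit > 10000 nM, so its standing is known only as a limit. The step that the two limits leave unreadable from compound 2 to compound 3 therefore cannot be sized. Compound 4 `COc1ccc(C(=O)/C=C/c2ccc(-n3ccnc3)cc2)c2c1C=CC(C)(C)O2` differs from compound 3 by 1H-imidazol-1-yl in place of phenyl on an aromatic carbon. Among the measured compounds shown here, no measured step reads out in numbers; the only bearing evidence is the limit of > 10000 nM in this assay, at which 2 of the 3 values shown sit, and compound 1 with its measured value lies close to that limit. In this assay no step beyond the scatter is expected for compound 4, with a step that the limit leaves unreadable from compound 3 to compound 4 taken as near zero. Compound 4 is estimated at 12000 nM, within 5000 nM to 40000 nM, most likely again reported as a limit.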

Compound 4, half-maximal inhibitory concentration: 7200 nM
Estimate against measurement, compound 4: 1.7-fold (0.22 log units) above; the range from low to high includes it.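

Among bromo, phenyl and 1H-imidazol-1-yl at this position, para to a large group, only 1H-imidazol-1-yl gives a measured number in this assay. The change reads as an at least 1.3-fold lower number from compound 3 to compound 4 (0.14 log units; that floor lies within the scatter) and as an at least 1.3-fold lower number from compound 2 to compound 4 (0.14 log units; that floor lies within the scatter), so these floors alone do not establish a real difference, though the true steps may be larger. The position so far stays close to the limit of the assay: the limit of > 10000 nM in this assay, at which 2 of the 4 values shown sit.

Going by these compounds, the true size of both steps remains open. Also open, on these data alone, is whether a basic amine or a carboxylic acid at this position would move the number clear of that limit.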